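The source may report more compounds than this note shows. Statements on the series, on what has been measured and on what is new or still open speak of the compounds shown alone.

Measured in a functional assay on HeLa cells (Homo sapiens) for inhibition, read by MTT assay, with a stated time of 72 h; a higher number here means a weaker inhibitor, a lower number a stronger inhibitor:
compound 1 `CN(C(=O)NC(=O)c1ccc(Cl)cc1Cl)c1nc(C(F)(F)F)c(C(=O)N/N=C/c2ccc(C(F)(F)F)cc2)s1` — 7.99 ug/mL
compound 2 `CN(C(=O)NC(=O)c1ccc(Cl)cc1Cl)c1nc(C(F)(F)F)c(C(=O)N/N=C/c2ccccc2C(F)(F)F)s1` — 9 ug/mL
compound 3 `CN(C(=O)NC(=O)c1c(F)cccc1F)c1nc(C(F)(F)F)c(C(=O)N/N=C/c2ccc(C(F)(F)F)cc2)s1` — 30.6 ug/mL

Compound 2 differs from compound 1 by 2-(trifluoromethyl)phenyl in place of 4-(trifluoromethyl)phenyl on a carbon with a double bond to nitrogen, and this change gave a 1.1-fold higher number from compound 1 to compound 2 (0.05 log units; within the scatter). The two cores differ by 2,6-difluorophenyl in place of 2,4-dichlorophenyl on a carbonyl carbon, which produced a 3.8-fold higher number from compound 1 to compound 3 (0.58 log units; beyond the scatter). Compound 4 `CN(C(=O)NC(=O)c1c(F)cccc1F)c1nc(C(F)(F)F)c(C(=O)N/N=C/c2ccccc2C(F)(F)F)s1` is still unmeasured; it differs from compound 3 by 2-(trifluoromethyl)phenyl in place of 4-(trifluoromethyl)phenyl on a carbon with a double bond to nitrogen, the same change as between compound 1 and compound 2, at a place described in identical words. The expected step, a 1.1-fold higher number from compound 3 to compound 4 (0.03 log units; within the scatter), is set beside the measured 1.1-fold higher number from compound 1 to compound 2 (0.05 log units; within the scatter). This expectation rests on compound 3, which gives 30.6 ug/mL, and on the near-unchanged result of the same change once before. Compound 4 is therefore expected to give about 33 ug/mL, most likely between 15 ug/mL and 70 ug/mL.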

Compound 4, half-maximal inhibitory concentration: 19.6 ug/mL
The estimate for compound 4 lay 1.7-fold (0.23 log units) above the measured number; measured number inside the range.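

In this assay, 2-(trifluoromethyl)phenyl in place of 4-(trifluoromethyl)phenyl gave a 1.6-fold lower number from compound 3 to compound 4 (0.19 log units; within the scatter) on the difluorinated core, so this change carried from one core to the other without a detectable difference: the same change on two cores in this assay, a 1.1-fold higher number (0.05 log units; within the scatter) from compound 1 to compound 2 and a 1.6-fold lower number (0.19 log units; within the scatter) from compound 3 to compound 4, 1.8-fold (0.25 log units) apart, within the scatter of two such steps.
Likewise, 2,6-difluorophenyl in place of 2,4-dichlorophenyl gave a 2.2-fold higher number from compound 2 to compound 4 (0.34 log units; beyond the scatter) and raised the number on both cores by a similar amount: the same change on two cores in this assay, a 3.8-fold higher number (0.58 log units; beyond the scatter) from compound 1 to compound 3 and a 2.2-fold higher number (0.34 log units; beyond the scatter) from compound 2 to compound 4, 1.8-fold (0.25 log units) apart, within the scatter of two such steps.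
Both changes thus carried over within these four compounds, but two cores in one assay do not show that this holds more widely, nor why it holds.

On these data alone, it remains open whether the same agreement would hold if an amine or a carboxylic acid replaced the trifluoromethyl group. The same question applies to a methoxy group or a bromine atom on the benzoyl ring.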